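Indane imidazole series: oxazolyl replaced by sulfonamide

The compounds below may be only part of what the source reports. "The series", "measured", "known", "first", "only" and "open" are said of these compounds alone.

Compound 1 `c1cncc(-c2cccc3c2CCC3c2ncc[nH]2)c1` gives 36% in a functional assay on CHO cells for agonist activity at Alpha-1A adrenergic receptor (Homo sapiens), read by FLIPR and calcium flux; on this read-out higher numbers stand for larger maximal responses and lower numbers for smaller maximal responses.
Compound 2 `CNC(=O)c1cccc2c1CCC2c1ncc[nH]1` gives 59% in this assay.
Compound 3 `c1cc(-c2ncco2)c2c(c1)C(c1ncc[nH]1)CC2` gives 63% in this assay.

Compound 3 has the highest of the three numbers. Its nearest neighbour is compound 2, whose number lies within the scatter (a number 4 percentage points higher from compound 2 to compound 3 (within the scatter)), so the two cannot be ordered. Compound 1 stands furthest away (a number 27 percentage points higher from compound 1 to compound 3 (beyond the scatter)), and compound 2 likewise stands clear of compound 1 (a number 23 percentage points higher from compound 1 to compound 2 (beyond the scatter)).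

Compound 4 `CCS(=O)(=O)Nc1cccc2c1CCC2c1ncc[nH]1` has not yet been measured. It differs from compound 3 in one place: (ethylsulfonyl)amino in place of 1,3-oxazol-2-yl on an aromatic carbon.

Among the measured compounds shown here, of the measured steps, the one from compound 2 to compound 3 bears most directly on this change, since both methylcarbamoyl and (ethylsulfonyl)amino bring one hydrogen-bond donor to the same aromatic carbon, whereas the oxazolyl and pyridinyl groups bring none; that step was within the scatter. The step from compound 1 to compound 3 is the only sizeable one, and it does not involve a donor-bearing group. For the measured compounds named here, no step moves the number by a large amount, so a step of no more than modest size is expected. The number for compound 4 is expected to sit near those of compound 2 and compound 3, with an estimated step of a number 8 percentage points lower from compound 3 to compound 4 (within the scatter). Compound 4 is thus estimated at 55%, between 35% and 75%.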

Compound 4, largest response reached (Emax), in percent of the reference or control that the assay uses: 86%
The estimate for compound 4 lay 31 percentage points below the measured number; measured number above the stated range.
By their numbers in this assay, from the lowest: compound 1; then compounds 2 and 3 (each within the scatter of the next); then compound 4.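

Putting (ethylsulfonyl)amino on this aromatic carbon gives a number 23 percentage points higher from compound 3 to compound 4 (beyond the scatter) in this assay and also a number 27 percentage points higher from compound 2 to compound 4 (beyond the scatter) with methylcarbamoyl as the group it replaces, so the level shared by compound 2 and compound 3 is not a ceiling for this position. Compound 2 also argues against reading the gain as a simple donor effect: its methylcarbamoyl group carries a hydrogen-bond donor, yet its number stays within the scatter of compound 3, whose 1,3-oxazol-2-yl group has none. The change from pyridin-3-yl gives a number 50 percentage points higher from compound 1 to compound 4 (beyond the scatter) and is the only large step among these compounds, which shows that this one substituent can move the maximal response widely on an otherwise unchanged core.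

Nothing available here explains why (ethylsulfonyl)amino stands out among these groups. Open questions are whether the gain depends on the ethyl chain, which a methylsulfonylamino or a propylsulfonylamino group would test, and whether it needs the sulfonyl unit at all, which a plain amine or a carboxylic acid on the same carbon would test.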